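A few compounds are considered here, and "the series" means these few. Any claim that something is new, unique, unknown or untested is made for them only; others in the source may bear on it.

Compound 1 `O=C(NCc1cc(Cl)ccc1-n1cnnn1)[C@@H]1CC=NN1C(=O)[C@H](O)c1ccccc1F` and compound 2 `CC1(C[C@@H](O)C(=O)N2N=CC[C@H]2C(=O)NCc2cc(Cl)ccc2-n2cnnn2)CC1` are two measured members of this series. In an ADME assay on Caco-2 cells (Homo sapiens) for permeability, read by LC-MS, in the apical to basolateral direction, with a stated time of 60 min, at pH 6.5 (a lower number here means that the compound crosses the layer more slowly, a higher number that the compound crosses the layer faster), compound 2 gives 9.5 10^-6 cm/s, and compound 1 gives 8.9 10^-6 cm/s. Going by the values given here, the single change between them, (2-fluorophenyl in place of (1-methylcyclopropyl)methyl on a saturated chain carbon bound to a carbonyl carbon and an oxygen on a saturated carbon), made a step of a 1.1-fold lower number from compound 2 to compound 1 (0.03 log units; within the scatter). Compound 3 `CC1(C[C@@H](O)C(=O)N2C[C@H]3C[C@H]3[C@H]2C(=O)NCc2cc(Cl)ccc2-n2cnnn2)CC1` is built on a different core; how that core differs from the core of compound 2 is not broken down here. In this assay compound 3 gives 2.2 10^-6 cm/s, the lowest of the three numbers, with compound 1 and compound 2 both lying beyond the scatter above it. Compound 4 `O=C(NCc1cc(Cl)ccc1-n1cnnn1)[C@@H]1[C@@H]2C[C@@H]2CN1C(=O)[C@H](O)c1ccccc1F` has not yet been measured. It arises from compound 3 by the same kind of change, (2-fluorophenyl in place of (1-methylcyclopropyl)methyl on a saturated chain carbon bound to a carbonyl carbon and an oxygen on a saturated carbon), at the same described place as before. A step of about the same size is expected, a 1.0-fold lower number from compound 3 to compound 4 (0.02 log units; within the scatter), because the earlier step of a 1.1-fold lower number from compound 2 to compound 1 (0.03 log units; within the scatter) stayed within the scatter and nothing here shows the change working differently on the core of compound 3. Compound 4 is therefore estimated at 2.1 10^-6 cm/s, most likely between 1 10^-6 cm/s and 4.5 10^-6 cm/s.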

Compound 4, apparent permeability: 2.3 10^-6 cm/s
For compound 4 the middle estimate is 1.1-fold (0.04 log units) below the measured one, and the stated range covers the measured number.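

In this assay, putting 2-fluorophenyl in place of (1-methylcyclopropyl)methyl gave a 1.0-fold higher number from compound 3 to compound 4 (0.02 log units; within the scatter), so this pair cannot be told apart, just like the earlier pair on the other core. Set side by side, the two steps agree, so in this small set the swap carries from one core to the other without a visible difference: the same change on two cores in this assay, a 1.1-fold lower number (0.03 log units; within the scatter) from compound 2 to compound 1 and a 1.0-fold higher number (0.02 log units; within the scatter) from compound 3 to compound 4, 1.1-fold (0.05 log units) apart, within the scatter of two such steps This is a narrow result, resting on only two cores and on one swap that gave no step beyond the scatter on either, so it does not show that a swap with a large step would carry over in the same way, nor that this one would hold on a third core.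

The compounds shown leave open what other groups on this saturated chain carbon would do, such as an amine, a carboxylic acid or a longer alkyl chain. They also leave open whether any such group would give steps of matching size on both cores.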